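The compounds below may be only part of what the source reports. "The series", "measured", "known", "first", "only" and "open" are said of these compounds alone.

Measured compounds:
compound 1 `CC1SC(c2cccc(C(=O)NCCCCc3ccccc3)c2)N(c2ccc(C3CC3)cc2)C1=O`: 3210 mL.min-1.g-1
compound 2 `COc1ccc(F)cc1N1C(=O)CSC1c1cccc(C(=O)NCCCCc2ccccc2)c1`: 2250 mL.min-1.g-1
compound 3 `O=C(NCCCCc1ccccc1)c1cccc(C2SCC(=O)N2c2ccccc2F)c1`: 2010 mL.min-1.g-1

These values come from an ADME assay on microsomes from liver (Mus musculus) for metabolic stability, read by LC-MS, using NADPH, with a stated time of 10 min, tested at 0.1 uM; on this read-out lower numbers stand for slow clearance and higher numbers for fast clearance. Compound 3 lies within the scatter of both compound 1 and compound 2, so the data show no real order among them.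

The next compound is compound 4 `O=C(NCCCCc1ccccc1)c1cccc(C2SCC(=O)N2c2ccc(C3CC3)cc2)c1`, which has 4-cyclopropylphenyl in place of 2-fluorophenyl on an amide-type nitrogen in a ring.

Two observations bear on this change. Among the measured compounds shown here, the only measured step at this nitrogen is a 1.1-fold lower number from compound 2 to compound 3 (0.05 log units; within the scatter), which is within the scatter, although it involves a different pair of groups. Compound 1 already carries the 4-cyclopropylphenyl group, but its core also bears a methyl, and it gives 3210 mL.min-1.g-1. That value is within the scatter of the value for compound 3. For the measured compounds named here, no measured step isolates the incoming group, so this evidence is indirect.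

On this basis, no change beyond the scatter is expected in this assay. The expected move is a 1.2-fold higher number from compound 3 to compound 4 (0.09 log units; within the scatter), with its direction left open by the scatter. The estimate for compound 4 is 2500 mL.min-1.g-1, with an expected range of 1400 mL.min-1.g-1 to 4400 mL.min-1.g-1.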

Compound 4, intrinsic clearance in microsomes: 2960 mL.min-1.g-1
Compound 4: the middle estimate sits 1.2-fold (0.07 log units) below what was measured, within the range that was stated.
By their numbers in this assay, from the lowest: compounds 3, 2, 4 and 1 (each within the scatter of the next).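

In this assay, 4-cyclopropylphenyl on the amide-type nitrogen now has direct comparisons with two other groups at this position: 2-fluorophenyl (a 1.5-fold higher number from compound 3 to compound 4 (0.17 log units; within the scatter)) and 5-fluoro-2-methoxyphenyl (a 1.3-fold higher number from compound 2 to compound 4 (0.12 log units; within the scatter)). Neither step separates the groups, so the intrinsic clearance read-out does not tell these three aryl groups apart in the compounds shown. The saturated ring carbon also gets its first single-place comparison (a 1.1-fold lower number from compound 1 to compound 4 (0.04 log units; within the scatter)), which does not separate hydrogen from methyl with 4-cyclopropylphenyl on the nitrogen, and no measurement shown here offers an explanation for any of these numbers.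

Every group shown on this nitrogen is a substituted phenyl, so it remains open whether a pyridine ring, or a phenyl carrying a carboxylic acid or an amine, would give a step beyond the scatter. The amide side chain is the same in all four compounds, which leaves open how a shorter chain or one carrying an ether oxygen would compare.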